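Ethoxyphenyl for benzoyl on the shared acid core

The compounds below may be only part of what the source reports. "The series", "measured", "known", "first", "only" and "open" are said of these compounds alone.

Compound 2 `O=C(O)c1ccc2c(C(=O)c3ccccc3)cc(C(=O)c3ccccc3)c-2cc1` gives 27% in an assay on cells for displacement of a labelled ligand from Orexin receptor type 2 (Homo sapiens), read by scintillation counting, with stated times of 10 min and 90 min, tested at 10 uM (on this read-out lower numbers stand for less inhibition and higher numbers for more inhibition at the one concentration tested (going by the name of the read-out)), the higher of the two numbers in hand; compound 1 `COC(=O)c1ccc2c(C(=O)c3ccccc3)cc(C(=O)c3ccccc3)c-2cc1` gives -14.5%. For the measured compounds named here, the one measured step, a number 41.5 percentage points higher from compound 1 to compound 2 (beyond the scatter), concerns a different part of the core. Going by the values given here, compound 3 `CCOc1ccc(-c2cc(C(=O)c3ccccc3)c3ccc(C(=O)O)ccc2-3)cc1` carries the change (4-ethoxyphenyl in place of benzoyl on an aromatic carbon), for which no measured step exists, so the estimate rests on compound 2 alone and expects no step beyond the scatter, a number 2 percentage points lower from compound 2 to compound 3 (within the scatter). Compound 3 is therefore expected to give 25%, in the range 0% to 50%.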

Compound 3, a percentage reported as inhibition, at one concentration (the size of the read-out at that concentration, not a potency): -16.9%
The estimate for compound 3 lay 41.9 percentage points above the measured number; the measured number lies below the stated range.
By their numbers in this assay, from the lowest: compounds 3 and 1 (each within the scatter of the next); then compound 2.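

In this assay, for the compounds shown here, 4-ethoxyphenyl in place of benzoyl on this aromatic carbon gives a number 43.9 percentage points lower from compound 2 to compound 3 (beyond the scatter), so this position matters as well as the acid site, the only place where the earlier compounds showed a step. Keeping the carboxylic acid does not by itself hold the number at the level of compound 2. Nothing at hand explains the drop.

The compounds shown leave open whether the drop follows from losing the carbonyl of benzoyl or from gaining the ethoxy group. A plain phenyl or a 4-methoxyphenyl at this position would bear on that.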